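The source may report more compounds than this note shows. Statements on the series, on what has been measured and on what is new or still open speak of the compounds shown alone.

Working notes on a small set of nitroimidazole-bearing oxadiazole thioethers tested in a functional assay on HepG2 cells (Homo sapiens) for cytotoxicity, read by MTT assay, with a stated time of 48 h; on this read-out lower numbers stand for stronger inhibition and higher numbers for weaker inhibition.

Three compounds have numbers. Compound 1 `COc1ccccc1-c1nnc(SCCn2c([N+](=O)[O-])cnc2C)o1` gives 10000 nM in this assay. Compound 2 `CCOc1ccc(-c2nnc(SCCn3c([N+](=O)[O-])cnc3C)o2)cc1` gives 1900 nM, and compound 3 `COc1cc(OC)cc(-c2nnc(SCCn3c([N+](=O)[O-])cnc3C)o2)c1` gives 10500 nM. Among these three numbers compound 1 stands second highest; its nearest neighbour is compound 3, whose number is within the scatter of repeated measurements, so no order between compound 1 and compound 3 can be claimed. The furthest is compound 2, whose number lies well beyond the scatter below that of compound 1, so compound 2 shows the stronger inhibition of the three measured compounds.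

Compound 4 `Cc1ncc([N+](=O)[O-])n1CCSc1nnc(-c2ccco2)o1` has not been measured. Relative to compound 1 the change is furan-2-yl in place of 2-methoxyphenyl on an aromatic carbon. Going by the values given here, no pair of measured compounds differs in exactly this way, so the size of this step cannot be read from the data; the only guide is that compound 1 and compound 3 sit close together while compound 2 stands apart.

Among the compounds with values here, with no comparable step available, the expectation for compound 4 is a number near that of compound 1, so the step of no change at the digits printed from compound 1 to compound 4 (within the scatter) is expected to stay within the scatter. Compound 4 is thus estimated at 10000 nM, with a range from 3500 nM to 30000 nM.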

Compound 4, half-maximal inhibitory concentration: 22600 nM
For compound 4 the middle estimate is 2.3-fold (0.35 log units) below the measured one; low and high end bracket the measured number.
By their numbers in this assay, from the lowest: compound 2; then compounds 1 and 3 (each within the scatter of the next); then compound 4.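

In this assay, going by these compounds alone, the aromatic carbon of the shared core that carries the aryl group proves sensitive to this exchange: furan-2-yl in place of 2-methoxyphenyl gives a 2.3-fold higher number from compound 1 to compound 4 (0.35 log units; beyond the scatter), the first single-place step, and it points to weaker inhibition, though only modestly. The two groups have the same counts of hydrogen-bond donors and acceptors, so those counts do not separate them; the change goes with a five-membered aromatic ring holding a hetero atom replacing a six-membered aromatic ring of carbon only, and with fewer heavy atoms. No measurement at hand bears on the cause of this step.

A single step cannot show whether it follows from the ring type, the group size or the loss of the methoxy group, and an unsubstituted phenyl or a thiophen-2-yl at this place would help to separate these. From the compounds shown here alone, how this position responds to a group carrying an amine or a carboxylic acid also remains open.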